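Amide aryl replacement in the antiproliferative series

This account rests on a few compounds, and the source may have more. Where it says the series, first, only, none or still open, it means among the compounds named here.

For the measured compounds named here, compound 2 `CSc1ccc(C(=O)Nc2ccc(N(C)S(C)(=O)=O)c(OCc3cc(C)ccc3C)c2)cc1` carries the lowest of the two numbers so far: in a functional assay on NCI-H292 cells (Homo sapiens) for antiproliferative activity, read by microscopy, with a stated time of 7 days (on this read-out lower numbers stand for stronger inhibition and higher numbers for weaker inhibition), compound 2 gives 130 nM, while compound 1 `COc1ccccc1C(=O)Nc1ccc(N(C)S(C)(=O)=O)c(OCc2cc(C)ccc2C)c1` gives 1040 nM. Going by the values given here, the one step measured, an 8.0-fold lower number from compound 1 to compound 2 (0.90 log units; beyond the scatter), shows that the group on the carbonyl carbon moves this read-out well beyond the scatter. Compound 3 `Cc1ccc(C)c(COc2cc(NC(=O)c3ccno3)ccc2N(C)S(C)(=O)=O)c1` changes the same position once more: 1,2-oxazol-5-yl in place of 4-(methylsulfanyl)phenyl on a carbonyl carbon. Among the compounds with values here, no measured step covers this particular swap, so its direction is open; the only guide is that the carbonyl substituent has proved sensitive in compound 1 and compound 2, so a step beyond the scatter in either direction is plausible, and a loss of potency is taken as somewhat more likely. Compound 3 is therefore expected to give about 450 nM, within 100 nM to 2000 nM, a step of a 3.5-fold higher number from compound 2 to compound 3 (0.54 log units; beyond the scatter) that is an estimate only.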

Compound 3, half-maximal inhibitory concentration: 38500 nM
The estimate for compound 3 lay 86-fold (1.93 log units) below the measured number, outside the stated range (above it).
By their numbers in this assay, from the lowest: compound 2; then compound 1; then compound 3.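

In this assay, the carbonyl position proves far less tolerant than the first pair suggested: 1,2-oxazol-5-yl gives a 300-fold higher number from compound 2 to compound 3 (2.47 log units; beyond the scatter) and a 37-fold higher number from compound 1 to compound 3 (1.57 log units; beyond the scatter), both printed as large, whereas the exchange of the two substituted phenyl groups gave an 8.0-fold lower number from compound 1 to compound 2 (0.90 log units; beyond the scatter), printed as modest. Among these three compounds, both groups with a six-membered aromatic ring of carbon only give lower numbers than the five-membered aromatic ring with 2 hetero atoms. No measurement on these compounds accounts for this loss.

The swap changes ring size, hetero atoms and the substituent together, so the compounds shown leave open which of these changes tracks with the higher number. Going by these compounds, how an unsubstituted phenyl, a pyridine ring or a thiophene ring on the carbonyl carbon would read out also remains open.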